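Thiazolo series: chloro for methoxy on the aryl arm

The compounds below may be only part of what the source reports. "The series", "measured", "known", "first", "only" and "open" are said of these compounds alone.

Measured so far:
compound 1 `C=C(Br)C(=O)Nc1cccc(-c2cn3nc(-c4cccs4)sc3n2)c1` — 170 nM
compound 2 `C=C(Br)C(=O)Nc1cccc(-c2cn3nc(-c4ccc(OC)cc4)sc3n2)c1` — 940 nM

Both compounds were run in a functional assay on L1210 cells (Mus musculus) for inhibition, read by cell counting, with a stated time of 2 days; on this read-out higher numbers stand for weaker inhibition and lower numbers for stronger inhibition. For the measured compounds named here, compound 2 gives the higher of the two numbers, and its only neighbour is compound 1, from which it is separated by a 5.5-fold higher number from compound 1 to compound 2 (0.74 log units; beyond the scatter). Going by the values given here, that step swaps one aryl arm for another and is the sole measured change in the set.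

Compound 3 `C=C(Br)C(=O)Nc1cccc(-c2cn3nc(-c4ccc(Cl)cc4)sc3n2)c1` differs from compound 2 by chloro in place of methoxy on an aromatic carbon. Among the compounds with values here, no measured step touches this substituent: the one step on hand exchanges a whole aryl arm rather than a single group on the six-membered aromatic ring, so it says nothing direct about trading methoxy for chloro para to a large group. The expectation therefore rests on the position of compound 2 alone and carries wide uncertainty.

For compound 3 a number somewhat below that of compound 2 is expected, perhaps 500 nM, within 150 nM to 1600 nM. The step expected is a 1.9-fold lower number from compound 2 to compound 3 (0.27 log units; within the scatter), which may well fall inside the scatter.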

Compound 3, half-maximal inhibitory concentration: 1400 nM
Estimate against measurement, compound 3: 2.8-fold (0.45 log units) below; low and high end bracket the measured number.
By their numbers in this assay, from the lowest: compound 1; then compounds 2 and 3 (each within the scatter of the next).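

In this assay, for the compounds shown here, chloro in place of methoxy on the six-membered aromatic ring, para to a large group, gives a 1.5-fold higher number from compound 2 to compound 3 (0.17 log units; within the scatter) and so shows no separable effect of this exchange, a single-group comparison that the earlier compounds could not supply. The distance from compound 1 now holds for a second aryl arm, with an 8.2-fold higher number from compound 1 to compound 3 (0.92 log units; beyond the scatter) standing in the same direction as a 5.5-fold higher number from compound 1 to compound 2 (0.74 log units; beyond the scatter) and both lying beyond the scatter. Among these three compounds, the exchange of thiophen-2-yl for either the 4-methoxyphenyl or the 4-chlorophenyl arm therefore counts for more than the exchange of methoxy for chloro, and none of the three goes against this reading. Nothing available bears on the reason for either result.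

As far as these compounds go, two substituents that read alike do not define the tolerance of this position, so it remains open whether an amine, a carboxylic acid or a longer chain such as butoxy would stay on the same level. Also open, from the compounds shown here alone, is whether a chloro or methoxy group on the thiophene ring of compound 1 would keep its lower number.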